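A few compounds are considered here, and "the series" means these few. Any claim that something is new, unique, unknown or untested is made for them only; others in the source may bear on it.

Going by the values given here, compound 2 `CN1CC(NC(=O)c2ccncc2Nc2cc(-c3ccc4ccn(C)c4c3)c3nccnc3c2)CCC1=O` is one of two compounds measured in a physicochemical assay for solubility, read by spectrophotometry, measured as kinetic solubility, at pH 8, tested at 500 uM; a lower number here means a less soluble compound, a higher number a more soluble compound; compound 2 gives 253 ug/mL, and compound 1 `CN1CCC(NC(=O)c2ccncc2Nc2cc(-c3ccc4ccn(C)c4c3)c3nccnc3c2)CC1` gives 246 ug/mL, two numbers that cannot be told apart in this assay. Among the compounds with values here, the single measured step, a 1.0-fold higher number from compound 1 to compound 2 (0.01 log units; within the scatter), swaps one ring for another on the amide-type nitrogen without moving the number. Compound 3 `CN1CCC(CNC(=O)c2ccncc2Nc2cc(-c3ccc4ccn(C)c4c3)c3nccnc3c2)C1` differs from compound 2 at the same position: (1-methylpyrrolidin-3-yl)methyl in place of 1-methyl-6-oxopiperidin-3-yl on an amide-type nitrogen. Within the data shown here, with only one step at that position, and that one flat, no shift beyond the scatter is expected, so the estimated step is a 1.1-fold lower number from compound 2 to compound 3 (0.04 log units; within the scatter). Compound 3 is therefore expected to give about 230 ug/mL, between 120 ug/mL and 260 ug/mL.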

Compound 3, solubility: 246 ug/mL
Compound 3: the middle estimate sits 1.1-fold (0.03 log units) below what was measured; the range from low to high includes it.
By their numbers in this assay, from the lowest: compounds 1, 3 and 2 (each within the scatter of the next).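

In this assay, this change also leaves the number in place: a 1.0-fold lower number from compound 2 to compound 3 (0.01 log units; within the scatter), and no change at the digits printed from compound 1 to compound 3 (within the scatter). All three compounds therefore sit within the scatter of one another, even though this swap on the amide-type nitrogen replaces a six-membered ring carrying a carbonyl with a five-membered ring without one, attached through an added carbon. Nothing available explains why the numbers stay together. Going by these compounds, it remains open whether an open-chain amine such as 2-(dimethylamino)ethyl, or a group carrying a carboxylic acid, would move the number beyond the scatter at this position.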